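Working notes: from compound 2 to compound 3

A few compounds are considered here, and "the series" means these few. Any claim that something is new, unique, unknown or untested is made for them only; others in the source may bear on it.

Measured in a functional assay on MCF7 cells (Homo sapiens) for inhibition, read by MTT assay, with a stated time of 48 h; a lower number here means a stronger inhibitor of growth, a higher number a weaker inhibitor of growth:
- compound 1 `Cn1cc(C2CC(c3ccccc3)=NN2C(=O)c2cccnc2)c2ccccc21` gives 7200 nM
- compound 2 `Cn1cc(C2CC(c3ccc(F)cc3)=NN2C(=O)c2cccnc2)c2cc(Br)ccc21` gives 480 nM

Of the two numbers, compound 2 has the lower, and its gap to compound 1 lies beyond the scatter. These two compounds differ in more than one place, so their values give no direct measure of a single change.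

The next compound is compound 3 `COc1ccc(C2=NN(C(=O)c3cccnc3)C(c3cn(C)c4ccc(Br)cc34)C2)cc1OC`, which has 3,4-dimethoxyphenyl in place of 4-fluorophenyl on a carbon with a double bond to nitrogen. Among the measured compounds shown here, no measured pair isolates this change, so the expectation is loose. A modest move to a higher number is expected, close to the edge of the scatter, with the estimated step being (a 1.7-fold higher number from compound 2 to compound 3 (0.22 log units; within the scatter)). For compound 3 the estimated value in this assay is 800 nM with an expected range from 250 nM to 2500 nM as its limits.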

Compound 3, concentration for 50% growth inhibition: 1170 nM
Compound 3: the middle estimate sits 1.5-fold (0.17 log units) below what was measured; low and high end bracket the measured number.
By their numbers in this assay, from the lowest: compound 2; then compound 3; then compound 1.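

In this assay, among the compounds shown here, placing 3,4-dimethoxyphenyl in place of 4-fluorophenyl on a carbon with a double bond to nitrogen gives the first single-place step (a 2.4-fold higher number from compound 2 to compound 3 (0.39 log units; beyond the scatter)). This shows that the group at this position affects growth inhibition: the exchange of 4-fluorophenyl for 3,4-dimethoxyphenyl, with 2 hydrogen-bond acceptors entering, weakens it by a modest step that lies beyond the scatter, without abolishing it. No measurement at hand gives a reason for this step.

The compounds shown cannot say whether one methoxy group alone would give the same step, or whether an amine on the same phenyl ring would sit nearer compound 2 or compound 3. On these data alone, the separate shares of the fluorine and the bromine in the gap between compound 1 and compound 2 also remain open.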